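Swapping Trifluoromethyl for Methyl on a Shared Core

The compounds below may be only part of what the source reports. "The series", "measured", "known", "first", "only" and "open" are said of these compounds alone.

Of the compounds shown here, three sharing one core have been measured in a functional assay on MCF7 cells (Homo sapiens) for inhibition, read by sulforhodamine B assay, with a stated time of 72 h; a lower number here means a stronger inhibitor, a higher number a weaker inhibitor. Compound 1 `CC(c1ccc(-c2ccccc2)c(F)c1)c1nnc2n1N=C(c1ccc(OC(F)(F)F)cc1)CS2` gives 4800 nM. Among the measured compounds shown here, compound 3 `CC(c1ccc(-c2ccccc2)c(F)c1)c1nnc2n1N=C(c1ccccc1)CS2` gives 7400 nM; the only change between them is hydrogen in place of trifluoromethoxy on an aromatic carbon, and the step of a 1.5-fold higher number from compound 1 to compound 3 (0.19 log units; within the scatter) lies within the scatter. Compound 2 `COc1ccc2cc(C(C)c3nnc4n3N=C(c3ccc(C(F)(F)F)cc3)CS4)ccc2c1` gives 6900 nM, the second highest of the three numbers; its gap to compound 3 and its gap to compound 1 are both within the scatter, so none of the three can be called stronger or weaker than another on these data.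

Compound 4 `COc1ccc2cc(C(C)c3nnc4n3N=C(c3ccc(C)cc3)CS4)ccc2c1` has not yet been measured. It differs from compound 2 in one place: methyl in place of trifluoromethyl on an aromatic carbon. For the measured compounds named here, the one measured step that bears on this change is the removal of a fluorine-bearing group from the same aromatic ring, which gave a 1.5-fold higher number from compound 1 to compound 3 (0.19 log units; within the scatter) and stayed within the scatter. Nothing in the measured compounds points to a larger effect from shrinking trifluoromethyl to methyl.

Compound 4 is therefore expected to give 7000 nM, with a range from 3000 nM to 16000 nM. For compound 4 the expected step is a 1.0-fold higher number from compound 2 to compound 4 (0.01 log units; within the scatter), nothing beyond the scatter.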

Compound 4, half-maximal inhibitory concentration: 11000 nM
For compound 4 the middle estimate is 1.6-fold (0.20 log units) below the measured one, and the stated range covers the measured number.
By their numbers in this assay, from the lowest: compounds 1, 2, 3 and 4 (each within the scatter of the next, the first and the last beyond it).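

Among the compounds shown here, on the aromatic carbon para to a large group, the first direct swap of trifluoromethyl for methyl in this assay gives a 1.6-fold higher number from compound 2 to compound 4 (0.20 log units; within the scatter), so replacing this group of 4 heavy atoms with one of 1 heavy atom yields a step that cannot be told apart from the ordinary spread of repeat measurements. The same ring position has now been changed twice, since the earlier step of a 1.5-fold higher number from compound 1 to compound 3 (0.19 log units; within the scatter) also stayed within that spread, and among the compounds shown no change here yet produces a clear difference in the number. Nothing shown here offers an explanation for the size of the new step.

From the compounds shown here alone, whether a group of a different kind at this position, such as an amine, a carboxylic acid or a longer alkyl chain, would move the number beyond the scatter remains open. The swap of trifluoromethyl for methyl is also seen here only with the side group of compound 2, so how it would read with the side group of compound 1 remains an open question.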